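Compound 3: methoxy to bromo, expected step

The compounds below may be only part of what the source reports. "The series", "measured", "known", "first", "only" and "open" are said of these compounds alone.

Measured in a functional assay on MCF7 cells (Homo sapiens) for inhibition, read by MTT assay, with a stated time of 48 h; a lower number here means a stronger inhibitor, a higher number a weaker inhibitor:
- compound 1 `Cc1ccc(/C=C2\SC(=O)N(CCNC(=O)Nc3c(C)n(C)n(-c4ccccc4)c3=O)C2=O)cc1`: 37400 nM
- compound 2 `COc1ccc(/C=C2\SC(=O)N(CCNC(=O)Nc3c(C)n(C)n(-c4ccccc4)c3=O)C2=O)cc1`: 5140 nM
- compound 3 `COc1ccc(/C=C2\SC(=O)N(CC(=O)Nc3c(C)n(C)n(-c4ccccc4)c3=O)C2=O)cc1`: 75600 nM

Compound 3, at 75600 nM, carries the highest number of the three. Compound 1 lies closest to it at 37400 nM, and compound 2 lies furthest at 5140 nM.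

The next structure is compound 4 `Cc1c(NC(=O)CN2C(=O)S/C(=C\c3ccc(Br)cc3)C2=O)c(=O)n(-c2ccccc2)n1C`, with bromo in place of methoxy on an aromatic carbon, para to a large group: bromo in place of methoxy on an aromatic carbon.

Going by the values given here, only one measured step bears on this change: a 7.3-fold lower number from compound 1 to compound 2 (0.86 log units; beyond the scatter). There, methoxy entered in place of methyl, so its loss in compound 4 points towards a higher number in this assay. Among the compounds with values here, the evidence is indirect, since that step does not involve compound 3 and no measured compound carries bromo. A smaller step than the measured one is therefore expected, leaning upward.

The estimate corresponds to a 1.3-fold higher number from compound 3 to compound 4 (0.12 log units; within the scatter), which is an expected step only. For compound 4 the estimated value is 100000 nM, with an expected range from 28000 nM to 300000 nM.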

Compound 4, half-maximal inhibitory concentration: 24100 nM
Estimate against measurement, compound 4: 4.1-fold (0.62 log units) above; measured number below the stated range.
By their numbers in this assay, from the lowest: compound 2; then compounds 4 and 1 (each within the scatter of the next); then compound 3.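

In this assay, bromo in place of methoxy on the 4-substituted phenyl gives a 3.1-fold lower number from compound 3 to compound 4 (0.50 log units; beyond the scatter) and so moves the number down, against the direction that the earlier methoxy step suggested. Methoxy therefore does not go with the lower number in every pair: methoxy in place of methyl gives a 7.3-fold lower number from compound 1 to compound 2 (0.86 log units; beyond the scatter) on one background, whereas on the background of compound 3 the methoxy compound has the higher number. These two steps involve different incoming or outgoing groups and different backgrounds, and no measurement here explains the difference between them.

As far as these compounds go, whether bromo gives a step in the same direction on the background of compound 2 remains open. Also open, from the compounds shown here alone, is how chloro, hydroxy or a dimethylamino group would compare with bromo at this place.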